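Anilino in Place of Piperidin-1-yl on the Shared Core

A few compounds are considered here, and "the series" means these few. Any claim that something is new, unique, unknown or untested is made for them only; others in the source may bear on it.

Compound 1 `CCCNc1nc(N)c(C(=O)N=C(N)N)nc1Cl`: 91%
Compound 2 `NC(N)=NC(=O)c1nc(Cl)c(NC2CC2)nc1N`: 78%
Compound 3 `NC(N)=NC(=O)c1nc(Cl)c(N2CCCCC2)nc1N`: 85%

In an assay for inhibition of acid-sensing ion channel 3 (Homo sapiens), read by patch clamp, tested at 20 uM (on this read-out higher numbers stand for more inhibition at the one concentration tested (going by the name of the read-out) and lower numbers for less inhibition), compound 3 stands second highest of the three numbers. The steps of a number 6 percentage points lower from compound 1 to compound 3 (within the scatter) and a number 7 percentage points higher from compound 2 to compound 3 (within the scatter) both lie within the scatter, so no order among the three can be claimed. Compound 4 `NC(N)=NC(=O)c1nc(Cl)c(Nc2ccccc2)nc1N` changes the same position: anilino in place of piperidin-1-yl on an aromatic carbon. The steps bearing on this are a number 6 percentage points lower from compound 1 to compound 3 (within the scatter) and a number 7 percentage points higher from compound 2 to compound 3 (within the scatter), neither beyond the scatter, while a number 13 percentage points lower from compound 1 to compound 2 (beyond the scatter) shows that exchanging groups at this carbon can shift the number modestly. Among the compounds with values here, no measured compound carries an aromatic group there. The estimated step is therefore a number 5 percentage points lower from compound 3 to compound 4 (within the scatter), a small change expected to stay within the scatter. Compound 4 is expected to give 80%, in a range from 60% to 95%.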

Compound 4, a percentage reported as inhibition, at one concentration (the size of the read-out at that concentration, not a potency): 95%
Estimate against measurement, compound 4: 15 percentage points below; measured number inside the range.
By their numbers in this assay, from the lowest: compounds 2, 3, 1 and 4 (each within the scatter of the next, the first and the last beyond it).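

In this assay, within the data shown here, anilino puts an aromatic ring at this position for the first time, and the reading stays high: a number 10 percentage points higher from compound 3 to compound 4 (within the scatter) and a number 4 percentage points higher from compound 1 to compound 4 (within the scatter) give no order. Only a number 17 percentage points higher from compound 2 to compound 4 (beyond the scatter) separates compound 4 from another compound, so this exchange can matter when cyclopropylamino is what leaves. No measured evidence explains these numbers. On these data alone, whether benzylamino, or an anilino carrying a carboxylic acid on its ring, would read the same remains open. With only one concentration tested, the potency of these compounds also remains open.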